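The source may hold more compounds than are shown below. What is called first, only, known or untested is meant among the compounds shown, and "the series" means these compounds.

Working notes on the oxazole series. Three compounds have numbers in an assay on HEK293 cells for inhibition of Voltage-dependent T-type calcium channel subunit alpha-1G (Homo sapiens), read by patch clamp; a lower number here means a stronger inhibitor, a higher number a weaker inhibitor. Compound 1 `CCCc1nc(-c2ccccc2)c(CNCCN2CCN(C(c3ccccc3)c3ccccc3)CC2)o1` gives 7470 nM. Compound 2 `CCCc1nc(-c2ccccc2)c(CNCCCN2CCN(c3cccc(C)c3)CC2)o1` gives 1190 nM. Compound 3 `CCCc1nc(-c2ccccc2)c(CNCCN2CCN(c3ccccc3)CC2)o1` gives 10300 nM. Compound 2 stands lowest of the three in this assay; its gap to compound 1 and its gap to compound 3 both lie beyond the scatter of repeated measurements, so compound 2 is the strongest inhibitor of the three measured. No two of these compounds differ in a single place, so no one-point step among measured compounds can be read off, and the three aryl or benzhydryl groups on the ring nitrogen vary together with the length of the chain that links the two amines.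

Compound 4 `CCCc1nc(-c2ccccc2)c(CNCCCN2CCN(c3ccc(Cl)cc3)CC2)o1` is not yet measured. It keeps the three-carbon chain of compound 2 and differs from it in one place:

4-chlorophenyl in place of 3-methylphenyl on an amine nitrogen in a ring

Going by the values given here, no measured pair shows what this exchange of one six-membered aromatic ring for another does in this assay. The expectation is a step from compound 2 to compound 4 of a 1.1-fold lower number from compound 2 to compound 4 (0.03 log units; within the scatter), that is, no change beyond the scatter. The value expected for compound 4 in this assay is 1100 nM, with a range from 350 nM to 3500 nM.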

Compound 4, half-maximal inhibitory concentration: 1310 nM
Estimate against measurement, compound 4: 1.2-fold (0.08 log units) below, and the stated range covers the measured number.
By their numbers in this assay, from the lowest: compounds 2 and 4 (each within the scatter of the next); then compounds 1 and 3 (each within the scatter of the next).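

Within this assay, putting 4-chlorophenyl in place of 3-methylphenyl on an amine nitrogen in a ring gives a 1.1-fold higher number from compound 2 to compound 4 (0.04 log units; within the scatter) and is the first step in the series that can be read at a single place; it shows no change beyond the scatter. At this position, therefore, one substituted six-membered aromatic ring of carbon only can stand in for another with the same counts of heavy atoms, hydrogen-bond donors and hydrogen-bond acceptors, although the two groups differ in both the substituent and where it sits on the ring, so this one step cannot separate those two differences. No measurement at hand accounts for the size of this step.

On these data alone, it remains open whether a methoxy group, a trifluoromethyl group or a nitrile on the aromatic ring, or a saturated cyclohexyl ring in its place, would move the number at this position. As far as these compounds go, the effect of the chain that links the two amines also remains open, since neither compound 1 nor compound 3 differs from compound 2 or compound 4 in one place only, and a longer chain would add a further point in that direction.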